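The source may report more compounds than this note shows. Statements on the series, on what has been measured and on what is new or still open speak of the compounds shown alone.

Measured compounds:
Compound 1 `Fc1ccc(C(OCCC2CCN(C/C=C/c3ccccc3)CC2)c2ccc(F)cc2)cc1`, in an assay on isolated protein for binding affinity to sodium-dependent dopamine transporter (Homo sapiens), read by radioligand binding; on this read-out higher numbers stand for weaker inhibition and lower numbers for stronger inhibition: 0.45 nM
Compound 2 `Fc1ccc(C(OCCC2CCN(C/C=C/c3cccs3)CC2)c2ccc(F)cc2)cc1`, in this assay: 1.3 nM

Compound 2 gives the higher of the two numbers seen so far, its nearest neighbour being compound 1 at a 2.9-fold higher number from compound 1 to compound 2 (0.46 log units; beyond the scatter). Compound 3 `Fc1ccc(C(OCCC2CCN(Cc3cccc4ccccc34)CC2)c2ccc(F)cc2)cc1` has not yet been measured. It differs from compound 2 by naphthalen-1-yl in place of 2-(thiophen-2-yl)ethenyl on a saturated chain carbon bound to an amine nitrogen in a ring. Among the measured compounds shown here, the one step known, the change from compound 1 to compound 2, swaps one aromatic ring for another while keeping the double bond in the chain, so it does not cover the shortening of the chain and the larger ring that enter here. For the measured compounds named here, with no step of the same kind to lean on, the expectation for compound 3 is a modest weakening beyond the scatter, a step of a 2.7-fold higher number from compound 2 to compound 3 (0.43 log units; beyond the scatter), and compound 3 is estimated at 3.5 nM with a range from 0.8 nM to 15 nM.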

Compound 3, inhibition constant: 16 nM
Beside the measured number, compound 3's estimate is 4.6-fold (0.66 log units) below it; the measured number lies above the stated range.
By their numbers in this assay, from the lowest: compound 1; then compound 2; then compound 3.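

In this assay, the group at this place, on a saturated chain carbon bound to an amine nitrogen in a ring, proves far less tolerant of change than the earlier swap of one aromatic ring for another suggested. Moving to naphthalen-1-yl gives a large step from either earlier compound (a 12-fold higher number from compound 2 to compound 3 (1.09 log units; beyond the scatter); a 36-fold higher number from compound 1 to compound 3 (1.55 log units; beyond the scatter)), whereas the only earlier step was modest (a 2.9-fold higher number from compound 1 to compound 2 (0.46 log units; beyond the scatter)). No measurement at hand explains this loss of binding.

The compounds shown leave open whether the shorter chain or the larger ring system matters more, since the two change together in compound 3. A benzyl group, or a naphthalen-1-yl carried on a prop-2-en-1-yl chain, would separate the two changes.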